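Trifluoromethyl in place of 2-oxopyrrolidin-1-yl

The source may hold more compounds than are shown below. What is called first, only, known or untested is meant among the compounds shown, and "the series" means these compounds.

In a functional assay on MDA-MB-231 cells (Homo sapiens) for inhibition, read by sulforhodamine B assay, with a stated time of 74 h (on this read-out lower numbers stand for stronger inhibition and higher numbers for weaker inhibition), compound 1 `Cc1ccc(S(=O)(=O)N2C(=O)COC23C=CC(=O)C=C3)cc1` gives 70 nM as a measured number. Compound 2 `O=C1C=CC2(C=C1)OCC(=O)N2S(=O)(=O)c1ccc([N+](=O)[O-])cc1` shows > 10000 nM only as a limit of the assay. Compound 3 `O=C1C=CC2(C=C1)OCC(=O)N2S(=O)(=O)c1ccc(N2CCCC2=O)cc1` shows > 10000 nM also only as a limit, so no number is known for it. Compound 4 `O=C1C=CC2(C=C1)OCC(=O)N2S(=O)(=O)c1ccc(C(F)(F)F)cc1` carries trifluoromethyl in place of 2-oxopyrrolidin-1-yl on an aromatic carbon, para to a large group (trifluoromethyl in place of 2-oxopyrrolidin-1-yl on an aromatic carbon). At that carbon the data show an at least 140-fold higher number from compound 1 to compound 3 (2.15 log units; beyond the scatter) and an at least 140-fold higher number from compound 1 to compound 2 (2.15 log units; beyond the scatter) as large changes, along with a step that the two limits leave unreadable from compound 2 to compound 3 between the two limits. Since compound 1 holds 70 nM with methyl there, a lower number is expected, though compound 2 with nitro goes against this. A limit of the assay remains possible for compound 4. The expected change is an at least 12-fold lower number from compound 3 to compound 4 (1.09 log units; beyond the scatter) in that direction. For compound 4 the estimate is 800 nM (expected range 80 nM to 10000 nM).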

Compound 4, half-maximal inhibitory concentration: 2100 nM
Compound 4: the middle estimate sits 2.6-fold (0.42 log units) below what was measured; the range from low to high includes it.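

In this assay trifluoromethyl, unlike nitro and 2-oxopyrrolidin-1-yl, gives a measured number at this aromatic carbon, with an at least 4.7-fold lower number from compound 3 to compound 4 (0.67 log units; beyond the scatter) and an at least 4.7-fold lower number from compound 2 to compound 4 (0.67 log units; beyond the scatter) as its steps. Methyl still gives the lower number, with a 30-fold higher number from compound 1 to compound 4 (1.48 log units; beyond the scatter) as the step, so activity at this carbon is graded rather than confined to methyl. The two steps from the limits give only a minimum size: the limit of > 10000 nM in this assay, at which 2 of the 4 values shown sit.

Going by these compounds, whether chlorine, methoxy or an amine at this carbon would fall nearer compound 1 or nearer compound 4 stays open. The true order of compound 2 and compound 3 cannot be read.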